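Ester Oxygen Substituent Variation: From Compound 2 to Compound 3

The source may report more compounds than this note shows. Statements on the series, on what has been measured and on what is new or still open speak of the compounds shown alone.

Among the measured compounds shown here, compound 2 `COC(=O)C1=C(C)NC(C)=C(C(=O)OC2CCCC2)C1c1csc(-c2ccc(Cl)cc2)n1` is one of two compounds measured in an assay on isolated protein for antagonist activity at Voltage-dependent L-type calcium channel subunit alpha-1C (Cavia porcellus), with a stated time of 15 min; on this read-out higher numbers stand for weaker inhibition and lower numbers for stronger inhibition. In this assay compound 2 gives 7290 nM, the highest of the two numbers recorded. Its nearest neighbour is compound 1 `COC(=O)C1=C(C)NC(C)=C(C(=O)OC)C1c1csc(-c2ccc(Cl)cc2)n1`, which in this assay gives 4430 nM. The step of a 1.6-fold higher number from compound 1 to compound 2 (0.22 log units; within the scatter) puts cyclopentyl in place of methyl on an oxygen next to a carbonyl group, and since it lies within the scatter the two values cannot be ordered.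

Compound 3 `COC(=O)C1=C(C)NC(C)=C(C(=O)OCCc2ccccc2)C1c1csc(-c2ccc(Cl)cc2)n1` has not yet been measured. It differs from compound 2 in one place: phenethyl in place of cyclopentyl on an oxygen next to a carbonyl group. For the measured compounds named here, the only measured step touching this position is a 1.6-fold higher number from compound 1 to compound 2 (0.22 log units; within the scatter), which stayed within the scatter. With a single change at this oxygen on record and no measurement of a phenethyl group anywhere in the set, there is no basis for expecting a step beyond the scatter in either direction. The expected step is a 1.1-fold lower number from compound 2 to compound 3 (0.05 log units; within the scatter), essentially flat. In this assay compound 3 is estimated at 6500 nM, with a range from 2500 nM to 17000 nM.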

Compound 3, half-maximal inhibitory concentration: 10200 nM
For compound 3 the middle estimate is 1.6-fold (0.20 log units) below the measured one, within the range that was stated.
By their numbers in this assay, from the lowest: compounds 1, 2 and 3 (each within the scatter of the next, the first and the last beyond it).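

In this assay the step of a 1.4-fold higher number from compound 2 to compound 3 (0.15 log units; within the scatter) stays inside the usual scatter, so phenethyl and cyclopentyl on this oxygen cannot be ordered, even though a six-membered aromatic ring replaces a five-membered non-aromatic ring. Among the compounds shown here, the first step at this oxygen to clear the scatter is a 2.3-fold higher number from compound 1 to compound 3 (0.36 log units; beyond the scatter) and it is modest in size, so the methyl and phenethyl groups can be told apart on this read-out, while compound 2 cannot be separated from either of them. Nothing available on these compounds accounts for this difference.

The compounds shown leave open how a benzyl group, a longer chain ending in an amine, or a carboxylic acid in place of this ester would read in this assay. Going by these compounds, all three compounds share the rest of the core, so what a fluorine in place of the chlorine would do at this channel also remains open.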